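Ethylsulfanyl for Cyclopropyl on an Antagonist Core

The compounds below may be only part of what the source reports. "The series", "measured", "known", "first", "only" and "open" are said of these compounds alone.

Compound 1, `c1ccc2oc(-c3cn4nc(C5CC5)sc4n3)cc2c1`, gives 530 nM in a functional assay on HEK293 cells for antagonist activity at proteinase-activated receptor 4 (Homo sapiens), read by FLIPR and calcium flux, with a stated time of 30 min; a higher number here means a weaker inhibitor, a lower number a stronger inhibitor.
Compound 2, `COc1cc(OCc2cccc(C#N)c2)c2cc(-c3cn4nc(OC)sc4n3)oc2c1`, gives 0.98 nM in this assay.

Of the two compounds measured, compound 1 stands at the highest number; compound 2 sits far lower, a gap well beyond the scatter, but compound 2 differs from compound 1 at several points at once, so the two values alone do not tell which change matters.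

Compound 3, `CCSc1nn2cc(-c3cc4ccccc4o3)nc2s1`, is compound 1 with one change: ethylsulfanyl in place of cyclopropyl on an aromatic carbon. For the measured compounds named here, no step between measured compounds isolates this change, so the expectation rests on the two values above and on the small size of the swap. The step from compound 1 to compound 3 is expected to be modest, a 1.8-fold lower number from compound 1 to compound 3 (0.25 log units; within the scatter), at the edge of the scatter and tending toward a lower number. Compound 3 is therefore estimated at 300 nM, within a range from 80 nM to 1200 nM.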

Compound 3, half-maximal inhibitory concentration: 2900 nM
Compound 3: the middle estimate sits 9.7-fold (0.99 log units) below what was measured; the measured number lies above the stated range.
By their numbers in this assay, from the lowest: compound 2; then compound 1; then compound 3.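

At this position on the shared core, the group is not interchangeable: in this assay, ethylsulfanyl in place of cyclopropyl gives a 5.5-fold higher number from compound 1 to compound 3 (0.74 log units; beyond the scatter), even though each group holds 3 heavy atoms. The earlier compounds shown here could not show this, as they differ at several points at once, whereas here a single change on an aromatic carbon of the five-membered aromatic ring with 2 nitrogen and 1 sulfur moves the number upward, and of these two groups cyclopropyl gives the lower number. No measurement shown accounts for the direction or size of this step.

From the compounds shown here alone, whether the same step would appear on the more heavily substituted core of compound 2 remains open. The compounds shown also leave open how an amine or a longer chain such as propyl would fare at this position.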